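A few compounds are considered here, and "the series" means these few. Any claim that something is new, unique, unknown or untested is made for them only; others in the source may bear on it.

Compound 1, `COc1ccc(NC(=O)CNCCCC(=O)Nc2ccccc2N)cc1`, in a functional assay on HCT-116 cells (Homo sapiens) for inhibition, read by MTT assay, with a stated time of 2 days (on this read-out lower numbers stand for higher toxicity in this test and higher numbers for lower toxicity in this test), gives > 100000 nM, which is a limit of the assay and not a number. Compound 2, `Nc1ccccc1NC(=O)CCCNCC(=O)Nc1cccc([N+](=O)[O-])c1`, in this assay likewise gives > 100000 nM, again only a limit. The step that the two limits leave unreadable from compound 1 to compound 2 is thus not readable, since both values sit at the limit of > 100000 nM in this assay, at which 2 of the 2 values shown sit. Compound 3, `Nc1ccccc1NC(=O)CCCNCC(=O)Nc1ccc(Cl)cc1`, differs from compound 2 by 4-chlorophenyl in place of 3-nitrophenyl on an amide-type nitrogen. No readable measured step bears on this change, so the expected step that the limit leaves unreadable from compound 2 to compound 3 rests on the two limits alone. Compound 3 is expected at 150000 nM, within 50000 nM to 500000 nM, most likely again reported only as a limit.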

Compound 3, concentration lethal to 50% of the cells: > 100000 nM
Compound 3: only a limit was reported; the forecaster's own chance of this, stated with the estimate: 80%; the middle value is on the limit's open side.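

Compound 3 gives > 100000 nM in this assay, which is a limit and not a number. Its steps from compound 1 and compound 2 therefore cannot be read: the limit of > 100000 nM in this assay, at which 3 of the 3 values shown sit.

The compounds shown leave open whether changing the group on the amide-type nitrogen alters toxicity in this assay at all.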